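Methylsulfanyl for methoxy on the shared core: compound 3

A few compounds are considered here, and "the series" means these few. Any claim that something is new, unique, unknown or untested is made for them only; others in the source may bear on it.

Compound 1 `COc1ccc(CNc2nc([Se]C)nc3ccccc23)cc1` was run in a functional assay on HT-29 cells (Homo sapiens) for cytotoxicity, read by MTT assay, with a stated time of 72 h; on this read-out higher numbers stand for weaker inhibition of growth and lower numbers for stronger inhibition of growth. In this assay compound 1 gives > 100000 nM, which is a limit of the assay and not a number. Compound 2 `COc1ccc(CNc2nc(SC)nc3ccccc23)cc1` differs only where a methylsulfanyl group replaces the methylselanyl group on the core. In this assay compound 2 gives > 100000 nM, again a limit. The step that the two limits leave unreadable from compound 1 to compound 2 is therefore not readable. Compound 3 `CSc1ccc(CNc2nc([Se]C)nc3ccccc23)cc1` carries methylsulfanyl in place of methoxy on an aromatic carbon. Going by the values given here, no measured step bears on this change, and both known values sit at the limit of > 100000 nM in this assay, at which 2 of the 2 values shown sit. Compound 3 is expected near 150000 nM, between 40000 nM and 600000 nM, most probably reported as a limit again. The expected step that the limit leaves unreadable from compound 1 to compound 3 is an estimate only.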

Compound 3, concentration for total growth inhibition: > 100000 nM
Compound 3: no number, only a limit (the forecaster's own chance of this, stated with the estimate: 80%); the middle value does not contradict the limit.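

Compound 3 gives only a limit of the assay, as compound 1 does, so no step from compound 1 to compound 3 can be read: the limit of > 100000 nM in this assay, at which 3 of the 3 values shown sit.

The compounds shown leave open how methylsulfanyl and methoxy compare on the shared core, and what actual number any of the three would give.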